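From pyridin-2-yl to piperazin-1-yl on a shared core

The compounds below may be only part of what the source reports. "The series", "measured", "known", "first", "only" and "open" are said of these compounds alone.

Of the compounds shown here, three sharing one core have been tested in a functional assay on MDA-MB-231 cells (Homo sapiens) for inhibition, read by MTT assay, with a stated time of 72 h (a higher number here means a weaker inhibitor, a lower number a stronger inhibitor), and differ in the group on an aromatic carbon next to the ring nitrogen. Compound 1 (`Cc1ccc(-c2cc(C(=O)N3CCC4(CC3)CC(=O)c3nn(C(C)(C)C)cc3O4)c3ccccc3n2)cc1`), with 4-methylphenyl, gives > 10000 nM as a limit of the assay and not a number. Compound 2 (`COc1ccc(-c2cc(C(=O)N3CCC4(CC3)CC(=O)c3nn(C(C)(C)C)cc3O4)c3ccccc3n2)cc1`), with 4-methoxyphenyl, gives > 10000 nM as a limit too. Among the compounds with values here, compound 3 (`CC(C)(C)n1cc2c(n1)C(=O)CC1(CCN(C(=O)c3cc(-c4ccccn4)nc4ccccc34)CC1)O2`), with pyridin-2-yl, gives 8100 nM as the only actual number of the three.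

Compound 4 (`CC(C)(C)n1cc2c(n1)C(=O)CC1(CCN(C(=O)c3cc(N4CCNCC4)nc4ccccc34)CC1)O2`) has not yet been measured. It differs from compound 3 by piperazin-1-yl in place of pyridin-2-yl on an aromatic carbon with piperazin-1-yl in place of pyridin-2-yl on that same aromatic carbon.

Within the data shown here, two measured steps touch this place: an at least 1.2-fold lower number from compound 1 to compound 3 (0.09 log units; that floor lies within the scatter) and an at least 1.2-fold lower number from compound 2 to compound 3 (0.09 log units; that floor lies within the scatter) are both floors within the scatter. Among the measured compounds shown here, neither puts a non-aromatic ring there, so the data hold no direct precedent for this change. With compound 3 at 8100 nM as the only reference, no clear shift in either direction can be argued, and the step expected is a 1.2-fold lower number from compound 3 to compound 4 (0.06 log units; within the scatter) with nothing beyond the scatter anticipated. Compound 4 is estimated at 7000 nM within an expected range of 2500 nM to 20000 nM in this assay.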

Compound 4, half-maximal inhibitory concentration: 4200 nM
Compound 4: the middle estimate sits 1.7-fold (0.22 log units) above what was measured; the range from low to high includes it.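

In this assay, within the data shown here, a non-aromatic ring on the aromatic carbon next to the ring nitrogen can now be read against the two substituted phenyl groups: the data show an at least 2.3-fold lower number from compound 2 to compound 4 (0.37 log units; beyond the scatter) and an at least 2.3-fold lower number from compound 1 to compound 4 (0.37 log units; beyond the scatter) as the first steps here that clear the scatter. Against pyridin-2-yl the picture differs, with a 1.9-fold lower number from compound 3 to compound 4 (0.29 log units; within the scatter) as the printed step, so these data do not separate piperazin-1-yl from pyridin-2-yl even though one ring is aromatic and the other is not. The two larger steps can be given only as floors because compound 1 and compound 2 each stand at a limit of the assay and not at a number: the limit of > 10000 nM in this assay, at which 2 of the 4 values shown sit.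

A morpholin-4-yl or a 4-methylpiperazin-1-yl at this place would show whether the step belongs to the non-aromatic ring as a whole or to its free ring amine. As far as these compounds go, an open-chain amine such as dimethylamino would show whether a ring is needed at all, and the true size of the steps from compound 1 and compound 2 also remains open.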